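The source may hold more compounds than are shown below. What is called first, only, known or untested is meant among the compounds shown, and "the series" means these compounds.

Measured compounds:
compound 1 `COc1ccc([C@@H]2CC(=O)c3c(O)cc(OCc4cn(Cc5ccc(C(F)(F)F)cc5)nn4)cc3O2)cc1O` — 17700 nM
compound 2 `CCn1cc(COc2cc(O)c3c(c2)O[C@H](c2ccc(OC)c(O)c2)C/C3=N\O)nn1` — 3140 nM
compound 3 `COc1ccc([C@@H]2C/C(=N\O)c3c(O)cc(OCc4cn(Cc5ccccc5F)nn4)cc3O2)cc1O` — 5710 nM

In a functional assay on RAW264.7 cells (Mus musculus) for inhibition, read by Griess assay, with stated times of 2 h and 24 h (on this read-out higher numbers stand for weaker inhibition and lower numbers for stronger inhibition), compound 1 gives the highest of the three numbers, standing beyond the scatter from both compound 3 and compound 2. Compound 4 `COc1ccc([C@@H]2CC(=O)c3c(O)cc(OCc4cn(Cc5ccccc5F)nn4)cc3O2)cc1O` differs from compound 1 by 2-fluorophenyl in place of 4-(trifluoromethyl)phenyl on a saturated chain carbon bound to an aromatic nitrogen. Among the measured compounds shown here, the one measured step at that position, a 1.8-fold higher number from compound 2 to compound 3 (0.26 log units; within the scatter), lies within the scatter, but it exchanges methyl rather than 4-(trifluoromethyl)phenyl and sits on a core that differs from that of compound 1, so it bears only loosely here. For the measured compounds named here, no measured pair compares a trifluoromethyl-bearing group with a fluorine-bearing one. The expected step, a 1.2-fold lower number from compound 1 to compound 4 (0.07 log units; within the scatter), stays within the scatter. Compound 4 is estimated at 15000 nM, with a range from 6000 nM to 40000 nM.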

Compound 4, half-maximal inhibitory concentration: 7320 nM
Compound 4: middle estimate off by 2.0-fold (0.31 log units), on the high side; measured number inside the range.
By their numbers in this assay, from the lowest: compounds 2, 3 and 4 (each within the scatter of the next, the first and the last beyond it); then compound 1.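

In this assay, the position on a saturated chain carbon bound to an aromatic nitrogen now shows a step beyond the scatter: with 2-fluorophenyl in place of 4-(trifluoromethyl)phenyl, the change is a 2.4-fold lower number from compound 1 to compound 4 (0.38 log units; beyond the scatter). Among the compounds shown here, the earlier step at this position stayed within the scatter, so this single pair is the first sign that the group held here can matter. Nothing available accounts for the difference. The compounds shown leave open whether the identity of the substituent or its location on the phenyl ring carries this step. They also leave open how an unsubstituted phenyl, a benzyl bearing a carboxylic acid or a longer chain would read here.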